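The source may hold more compounds than are shown below. What is called first, only, known or untested is meant among the compounds shown, and "the series" means these compounds.

Compound 1 `O=C1c2ccc(Cl)cc2CN1c1cccnc1` carries a chloro group on its aromatic ring. In an assay on cells for inhibition of cytochrome P450 11B2, mitochondrial (Homo sapiens), read by HTRF (on this read-out higher numbers stand for weaker inhibition and lower numbers for stronger inhibition), compound 1 gives 179 nM. Its two companions differ only on the saturated ring carbon: compound 3 `CC1c2cc(Cl)ccc2C(=O)N1c1cccnc1` gives 123 nM and compound 2 `CCC1c2cc(Cl)ccc2C(=O)N1c1cccnc1` gives 121 nM, so the steps of a 1.5-fold lower number from compound 1 to compound 3 (0.16 log units; within the scatter) and a 1.5-fold lower number from compound 1 to compound 2 (0.17 log units; within the scatter) both stay within the scatter, as does a 1.0-fold higher number from compound 2 to compound 3 (0.01 log units; within the scatter). Compound 4 `N#Cc1ccc2c(c1)CN(c1cccnc1)C2=O` differs from compound 1 by cyano in place of chloro on an aromatic carbon. Within the data shown here, none of the measured steps touches that aromatic position, so no step bears directly on this change; the measured steps were all within the scatter, and a step of similar size is expected, a 1.2-fold lower number from compound 1 to compound 4 (0.08 log units; within the scatter). Compound 4 is therefore estimated at 150 nM, between 50 nM and 500 nM.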

Compound 4, half-maximal inhibitory concentration in the cytochrome P450 11B2, mitochondrial assay: 232 nM
Estimate against measurement, compound 4: 1.5-fold (0.19 log units) below; measured number inside the range.
By their numbers in the cytochrome P450 11B2, mitochondrial assay, from the lowest: compounds 2, 3, 1 and 4 (each within the scatter of the next).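

Among these compounds, in the cytochrome P450 11B2, mitochondrial assay cyano in place of chloro on this aromatic carbon gives a 1.3-fold higher number from compound 1 to compound 4 (0.11 log units; within the scatter) and so stays within the scatter, which the earlier compounds, varied only on the saturated ring carbon, could not show. In a physicochemical assay for lipophilicity, measured as octanol-water partition (on this read-out higher numbers stand for higher lipophilicity and lower numbers for lower lipophilicity), compound 1 gives 2.52 and compound 4 gives 1.35. In the physicochemical assay the same change has a large effect, so lipophilicity at this position moves without a matching move in inhibition: the measured distribution coefficient of compound 1, 2.52, and of compound 4, 1.35, a number 1.17 log units lower (beyond the scatter).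

On these data alone, whether an amine or a carboxylic acid on this aromatic carbon would also leave inhibition within the scatter stays open. So does whether cyano would give a similar step on the methyl and ethyl compounds.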